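Two Inverted Centres: Expected Stability of Compound 4

The source may report more compounds than this note shows. Statements on the series, on what has been measured and on what is new or still open speak of the compounds shown alone.

Measured so far:
compound 1 `O=C(N[C@H](CO)C(=O)O)[C@@H]1C[C@@H](O)CN1` — 0.99 h
compound 2 `O=C(O)[C@H](CO)NC(=O)[C@H]1C[C@H](O)CN1` — > 12 h
compound 3 `O=C(O)[C@H](CO)NC(=O)[C@@H]1C[C@H](O)CN1` — 1.15 h

In an ADME assay (Mus musculus, strain C57BL/6) for metabolic stability, read by HPLC, with a stated time of 12 h (a lower number here means that the compound disappears faster, a higher number that the compound lasts longer), compound 1 gives 0.99 h and compound 3 gives 1.15 h, so compound 3 has the higher of the two numbers, but the step of a 1.2-fold higher number from compound 1 to compound 3 (0.07 log units; within the scatter) shows this gap is not meaningful. Compound 2 reaches only the limit of this assay, > 12 h. Compound 4 `O=C(O)[C@@H](CO)NC(=O)[C@H]1C[C@H](O)CN1` has not been measured. Its change from compound 3 is the two compounds have the same atoms and bonds and differ only in configuration as drawn: 2 of 3 stereo elements differ; a stereocentre at a saturated chain carbon is drawn S in compound 3 and R in compound 4; a stereocentre at a saturated ring carbon is drawn S in compound 3 and R in compound 4. Among the measured compounds shown here, two measured steps bear on this. The step of an at least 10-fold lower number from compound 2 to compound 3 (1.01 log units; beyond the scatter) involves the same ring carbon in the opposite direction, and compound 4 carries the ring configuration of compound 2. The step of a 1.2-fold higher number from compound 1 to compound 3 (0.07 log units; within the scatter) inverts a chain carbon together with a ring carbon, and the two compounds differ only in configuration, as noted in the fact that compounds 1 and 3 differ only in the configuration as drawn. A clearly higher number is therefore expected for compound 4, a 5.2-fold higher number from compound 3 to compound 4 (0.72 log units; beyond the scatter), with the size uncertain. Compound 4 is estimated at 6 h, in the range 1.5 h to 12 h.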

Compound 4, half-life: > 12 h
Compound 4: no number, only a limit (the forecaster's own chance of this, stated with the estimate: 35%); at least 2.0-fold (0.30 log units) between middle value and limit.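

In this assay compound 4 gives > 12 h, which is a limit of the assay and not a number. Compound 4 keeps the chain carbon of compound 1 and inverts both ring carbons, and that change alone gives an at least 12-fold higher number from compound 1 to compound 4 (1.08 log units; beyond the scatter), so this chain configuration does not by itself hold the half-life down. The ring configuration shared by compounds 2 and 4 now goes with a limit value under either chain configuration, and an at least 10-fold higher number from compound 3 to compound 4 (1.01 log units; beyond the scatter) arises with no atom gained or lost: the fact that compounds 3 and 4 differ only in the configuration as drawn

From the compounds shown here alone, the step from compound 2 to compound 4 cannot be read, so any effect of the chain carbon within this ring configuration stays unknown. Going by these compounds, it is also open whether the long half-life would survive a methyl ester in place of the carboxylic acid.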